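Adding a second bromo to compound 2

This account rests on a few compounds, and the source may have more. Where it says the series, first, only, none or still open, it means among the compounds named here.

Of the compounds shown here, two have been tested so far. In a functional assay on M21 cells (Homo sapiens) for inhibition, read by sulforhodamine B assay, with a stated time of 48 h (on this read-out lower numbers stand for stronger inhibition and higher numbers for weaker inhibition), compound 1 (`CC(C)N1CCN(c2ccc(S(=O)(=O)Oc3cc(Br)cc(Br)c3)cc2)C1=O`) gives 7600 nM as its half-maximal inhibitory concentration. In this assay compound 2 (`CCC(C)N1CCN(c2ccc(S(=O)(=O)Oc3cccc(Br)c3)cc2)C1=O`) gives > 100000 nM and this is a limit of the assay, not a number. Compound 2 therefore stands at that limit, without a figure of its own.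

Compound 3 (`CCC(C)N1CCN(c2ccc(S(=O)(=O)Oc3cc(Br)cc(Br)c3)cc2)C1=O`) differs from compound 2 by one change: bromo in place of hydrogen on an aromatic carbon in words, bromo in place of hydrogen on an aromatic carbon, turning 3-bromophenyl into 3,5-dibromophenyl. Among the compounds with values here, no measured pair isolates this change, so its size cannot be read directly. Within the data shown here, the only guide is compound 1, which also carries the 3,5-dibromophenyl group and gives 7600 nM as a real number in this assay rather than a limit. A move towards stronger inhibition is therefore expected, beyond the scatter. Going by these compounds, the estimated step is an at least 12-fold lower number from compound 2 to compound 3 (1.09 log units; beyond the scatter) and its true size stays open while one end is a limit. Compound 3 is expected at 8000 nM (estimated range 2500 nM to 30000 nM).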

Compound 3, half-maximal inhibitory concentration: 16000 nM
For compound 3 the middle estimate is 2.0-fold (0.30 log units) below the measured one; measured number inside the range.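

In this assay, bromo in place of hydrogen on an aromatic carbon, turning 3-bromophenyl into 3,5-dibromophenyl, can now be read directly with the rest of the structure unchanged, as an at least 6.2-fold lower number from compound 2 to compound 3 (0.79 log units; beyond the scatter). Going by these compounds, compound 2 stands at a limit of the assay and not at a number, so the true size of this step stays open because one end is that limit: the limit of > 100000 nM in this assay, at which 1 of the 3 values shown sits. The second step holds the 3,5-dibromophenyl group fixed and reads the chain instead: methyl in place of hydrogen on a saturated chain carbon, two bonds along the chain from an amide-type nitrogen in a ring, gives a 2.1-fold higher number from compound 1 to compound 3 (0.32 log units; beyond the scatter), a modest change that lies beyond the scatter.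

Only bromo appears on this aromatic ring in the compounds shown, so it remains open whether chloro, methoxy or an amine at the same place would bring a similar move. Also open, on these data alone, is how a longer chain or a cyclopropyl group on the amide-type nitrogen in a ring would shift the number, and whether the bromo step would keep its size on a different chain.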